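Exchanging One Aromatic Ring Beside the Carbonyl

A few compounds are considered here, and "the series" means these few. Any claim that something is new, unique, unknown or untested is made for them only; others in the source may bear on it.

Compound 1, `Cn1cccc1C(=O)/C=C/c1ccc2c(c1)B(O)OC2`, in a toxicity assay on WI-38 cells (Homo sapiens) for cytotoxicity, read by MTT assay, with a stated time of 48 h; a higher number here means a weaker inhibitor, a lower number a stronger inhibitor: > 100000 nM
Compound 2, `O=C(/C=C/c1ccc2c(c1)B(O)OC2)c1ccc([N+](=O)[O-])cc1`: 39300 nM
Compound 3, `O=C(/C=C/c1ccc2c(c1)B(O)OC2)c1ccc(Cl)c(Cl)c1`: 12500 nM

Three compounds share a core and differ only in the aromatic ring attached to the carbonyl carbon. For compound 1 the result is a limit of the assay and not a number, so its true value is known only as lying beyond (the limit of > 100000 nM in this assay, at which 1 of the 3 values shown sits). Compound 2 gives 39300 nM and compound 3 gives 12500 nM, both numbers rather than limits.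

Compound 4, `Cc1cccc(C(=O)/C=C/c2ccc3c(c2)B(O)OC3)c1`, has not been measured in this assay. It differs from compound 1 in one place: 3-methylphenyl in place of 1-methyl-1H-pyrrol-2-yl on a carbonyl carbon.

Within the data shown here, no measured pair differs in exactly one place, so the size of this step cannot be read from the data. Because compound 1 sits at the limit (the limit of > 100000 nM in this assay, at which 1 of the 3 values shown sits), only a step toward a stronger inhibitor, or none detectable, can show. The two measured aryl ketones, compound 2 and compound 3, give numbers below that limit, so compound 4 is expected to land near them, with an expected step of an at least 2.0-fold lower number from compound 1 to compound 4 (0.30 log units; that floor lies within the scatter). Compound 4 is estimated at 50000 nM, within 15000 nM to 150000 nM.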

Compound 4, half-maximal inhibitory concentration: 16700 nM
For compound 4 the middle estimate is 3.0-fold (0.48 log units) above the measured one, within the range that was stated.
By their numbers in this assay, from the lowest: compounds 3 and 4 (each within the scatter of the next); then compound 2. At a limit, above all of these: compound 1.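

In this assay, among these compounds, 3-methylphenyl in place of 1-methyl-1H-pyrrol-2-yl on a carbonyl carbon gives an at least 5.9-fold lower number from compound 1 to compound 4 (0.77 log units; beyond the scatter) as the first step here that can be read across a single change. This shows that exchanging the ring at this carbonyl carbon, with the shared core untouched, can by itself move the reading by more than the usual scatter. The figure gives only the smallest possible size of the step, and the true size stays unknown, because compound 1 sits at a limit of the assay: the limit of > 100000 nM in this assay, at which 1 of the 4 values shown sits.

The change replaces the ring size, the ring nitrogen and the position of the methyl all at once, so the compounds shown do not tell which of these matters. They also leave open how the reading responds to a plain phenyl at this carbonyl carbon, or to an amine or a carboxylic acid on the phenyl ring.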